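Swapping a pyrrolidine for an azetidine on compound 2

The source may report more compounds than this note shows. Statements on the series, on what has been measured and on what is new or still open speak of the compounds shown alone.

Compound 1 `CCC(=O)Nc1cc(C(=O)Nc2ccc(N3CCN(C)CC3)cc2)ccc1OC`: > 200000 nM (a limit of the assay)
Compound 2 `CN(C)C1CCN(Cc2ccc(NC(=O)c3ccc(OCCCCl)c([N+](=O)[O-])c3)cc2C(F)(F)F)C1`: 5800 nM
Compound 3 `CCC(=O)Nc1cc(C(=O)Nn2c(C)nnc2S)ccc1OC`: > 200000 nM (a limit of the assay)

Of these three, only compound 2 gives an actual number in a toxicity assay on Huh-7.5 cells (Homo sapiens) for inhibition, read by MTT assay, with a stated time of 96 h (on this read-out lower numbers stand for higher toxicity in this test and higher numbers for lower toxicity in this test), at 5800 nM. Compound 1 and compound 3 give no number, only a limit: the limit of > 200000 nM in this assay, at which 2 of the 3 values shown sit.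

The next compound to be tested is compound 4 `CN(C)C1CN(Cc2ccc(NC(=O)c3ccc(OCCCCl)c([N+](=O)[O-])c3)cc2C(F)(F)F)C1`, which differs from compound 2 in one place: 3-(dimethylamino)azetidin-1-yl in place of 3-(dimethylamino)pyrrolidin-1-yl on a saturated chain carbon bound to an aromatic carbon. Here 3-(dimethylamino)azetidin-1-yl stands in place of 3-(dimethylamino)pyrrolidin-1-yl, so a four-membered non-aromatic ring replaces a five-membered one. Among the measured compounds shown here, no measured pair in this set shows a change of this kind, and the expectation rests on compound 2 alone, at 5800 nM. The estimated step of a 1.0-fold higher number from compound 2 to compound 4 (0.01 log units; within the scatter) in this assay is expected to stay within the scatter, with no direction favoured. The expected value for compound 4 is 6000 nM. The estimated range runs from 2500 nM to 14000 nM.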

Compound 4, half-maximal cytotoxic concentration: 7800 nM
Beside the measured number, compound 4's estimate is 1.3-fold (0.11 log units) below it; the measured number falls inside the stated range.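

In this assay, the change reads as a 1.3-fold higher number from compound 2 to compound 4 (0.13 log units; within the scatter), so at this saturated chain carbon bound to an aromatic carbon, the four-membered ring and the five-membered ring cannot be told apart on this read-out. Among the compounds shown here, compound 4 also gives an actual number rather than a limit, and this is the first pair to show that 3-(dimethylamino)azetidin-1-yl can stand in place of 3-(dimethylamino)pyrrolidin-1-yl without a change beyond the scatter. Nothing shown here accounts for this result.

The compounds shown leave open how a six-membered piperidine carrying the same dimethylamino group, or a morpholine, would read at this place. They also leave open whether a carboxylic acid at this place would move the number beyond the scatter.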